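The source may report more compounds than this note shows. Statements on the series, on what has been measured and on what is new or still open speak of the compounds shown alone.

Measured so far in a functional assay on HEK293 cells for agonist activity at trace amine-associated receptor 1 (Homo sapiens), read by cAMP accumulation, with a stated time of 30 min; a higher number here means that more compound is needed for the effect, a lower number that less compound is needed:
compound 1 `CCN(C[C@@H]1COC(N)=N1)c1ccccc1` gives 230 nM
compound 2 `NC1=N[C@@H](c2ccccc2Cl)CO1` gives 23 nM

Within the data shown here, compound 2 stands lowest of the two numbers; compound 1 sits a step above it that lies beyond the scatter, though no single-point step links the two. Compound 3 `Cc1ccccc1[C@H]1COC(N)=N1` is the not yet measured follow-up; from compound 2 it differs by methyl in place of chloro on an aromatic carbon. Among the measured compounds shown here, no step of this kind has been measured, so the expectation rests on compound 2 alone: a small move upward, near the edge of the scatter, is expected, a 1.7-fold higher number from compound 2 to compound 3 (0.24 log units; within the scatter). Compound 3 is thus estimated at 40 nM, within 15 nM to 120 nM.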

Compound 3, half-maximal effective concentration: 67 nM
Compound 3: middle estimate off by 1.7-fold (0.22 log units), on the low side; measured number inside the range.
By their numbers in this assay, from the lowest: compound 2; then compound 3; then compound 1.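

In this assay, the aromatic carbon ortho to a group of 6 heavy atoms responds to a swap of one heavy atom for another: methyl in place of chloro gives a 2.9-fold higher number from compound 2 to compound 3 (0.46 log units; beyond the scatter), a modest step. The two groups have the same counts of hydrogen-bond donors and acceptors and neither carries a net charge, so the step appears with those counts unchanged. No measurement at hand accounts for the step.

Going by these compounds, how fluoro, methoxy or a nitrile on this carbon would read remains open. Also open, on these data alone, is whether chloro keeps its lower number on other carbons of the aromatic ring.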